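Toward a smaller aryl group on a weakly cytotoxic triazole

The source may hold more compounds than are shown below. What is called first, only, known or untested is meant among the compounds shown, and "the series" means these compounds.

Going by the values given here, compound 1 `CC(C)(C)c1ccc(-c2nnc(SCCCN3CCN(c4ccccc4)CC3)[nH]2)cc1` is the only member of this small set that returns a number in a functional assay on THP-1 cells (Homo sapiens) for cytotoxicity, read by MTT assay, with a stated time of 24 h; on this read-out higher numbers stand for weaker inhibition and lower numbers for stronger inhibition: compound 1 gives 97600 nM. Compound 2 `Cc1ccc(-c2nnc(SCCCN3CCN(c4cccc(Cl)c4)CC3)[nH]2)cc1` reaches only a limit of the assay, since compound 2 gives > 300000 nM in this assay. Compound 3 `Clc1ccc(-c2nnc(SCCCN3CCN(c4cccc(Cl)c4)CC3)[nH]2)cc1` likewise stops at a limit, with compound 3 giving > 300000 nM. Among the compounds with values here, the one step between measured compounds that differ in a single place, a step that the two limits leave unreadable from compound 2 to compound 3, cannot be read in size because of the limit of > 300000 nM in this assay, at which 2 of the 3 values shown sit.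

Compound 4 `Cc1cccc(-c2nnc(SCCCN3CCN(c4ccccc4)CC3)[nH]2)c1` is the untested member. It differs from compound 1 in one place: 3-methylphenyl in place of 4-(tert-butyl)phenyl on an aromatic carbon. Within the data shown here, no measured pair changes this group alone, so no step bears directly on it; what is known is that compound 1 sits on the number side of the data while the two other compounds sit at the limit. Among the measured compounds shown here, the change removes three carbons from the aryl group attached to the shared core and moves the remaining substituent, and the set gives no step by which to weigh either part.

Compound 4 is therefore expected to land in this assay at about 200000 nM, within a range from 70000 nM to 400000 nM. The estimated step from compound 1 to compound 4 is a 2.0-fold higher number from compound 1 to compound 4 (0.31 log units; beyond the scatter), toward weaker inhibition, with a real chance that only a limit is reported.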

Compound 4, half-maximal inhibitory concentration: 248000 nM
Estimate against measurement, compound 4: 1.2-fold (0.09 log units) below; the measured number falls inside the stated range.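

In this assay, going by these compounds alone, 3-methylphenyl in place of 4-(tert-butyl)phenyl on the aromatic carbon of the shared core gives a 2.5-fold higher number from compound 1 to compound 4 (0.41 log units; beyond the scatter), toward weaker inhibition, and this is the first step in the set whose size can be read. It shows that this position responds to the aryl group, modestly but beyond the usual scatter, as the group goes from 10 heavy atoms to 7 and its substituent changes place. Compound 4 still returns a number and not a limit, so the change leaves the read-out on the measurable side of the assay's limit: the limit of > 300000 nM in this assay, at which 2 of the 4 values shown sit.

Within the data shown here, the single step joins two changes, the smaller substituent and its new place on the aryl group, and it cannot divide the effect between them, while the step between the two compounds at the limit remains unreadable. Also open, going by these compounds, is how an unsubstituted phenyl group, or an aryl group bearing a carboxylic acid or an amine, would read at this same carbon, and whether any such group would stop at the limit.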